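Methoxy for Methyl on a Second Triazole Core

A few compounds are considered here, and "the series" means these few. Any claim that something is new, unique, unknown or untested is made for them only; others in the source may bear on it.

Measured so far:
compound 1, `Cc1ccccc1Nc1ncnn1-c1cccc(Cl)c1Cl`, 17.8 nM;
compound 2, `COc1ccccc1Nc1ncnn1-c1cccc(Cl)c1Cl`, 102 nM;
compound 3, `Cc1ccccc1CNc1ncnn1-c1cccc(Cl)c1Cl`, 20.9 nM.

These three compounds were tested in a functional assay for antagonist activity at P2X purinoceptor 7 (Homo sapiens), read by FLIPR and calcium flux; on this read-out lower numbers stand for stronger inhibition and higher numbers for weaker inhibition. Compound 1 and compound 3 give numbers that lie within the scatter of each other, so no order between them can be read from these data. Compound 2 stands apart: the step of a 5.7-fold higher number from compound 1 to compound 2 (0.76 log units; beyond the scatter), the change being (methoxy in place of methyl on an aromatic carbon).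

Compound 4, `COc1ccccc1CNc1ncnn1-c1cccc(Cl)c1Cl`, has not yet been measured. It carries the same change relative to compound 3, namely (methoxy in place of methyl on an aromatic carbon). The place line is the same word for word in both pairs, so this is the same change, made on a different core. How the core of compound 3 differs from the core of compound 1 is not broken down here.

Because the same change gave a 5.7-fold higher number from compound 1 to compound 2 (0.76 log units; beyond the scatter), a step of similar size is expected for compound 4, that is a 4.8-fold higher number from compound 3 to compound 4 (0.68 log units; beyond the scatter). Compound 4 is therefore estimated at 100 nM, with a likely range from 40 nM to 300 nM.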

Compound 4, half-maximal inhibitory concentration: 57.5 nM
Compound 4: the middle estimate sits 1.7-fold (0.24 log units) above what was measured; low and high end bracket the measured number.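

In this assay, methoxy in place of methyl on an aromatic carbon gives a 2.8-fold higher number from compound 3 to compound 4 (0.44 log units; beyond the scatter) on the second core, so the change again moves the read-out toward weaker inhibition. Set beside the earlier step, the new one points the same way, and the two sizes cannot be told apart: the same change on two cores in this assay, a 5.7-fold higher number (0.76 log units; beyond the scatter) from compound 1 to compound 2 and a 2.8-fold higher number (0.44 log units; beyond the scatter) from compound 3 to compound 4, 2.1-fold (0.32 log units) apart, within the scatter of two such steps. This supports carrying the change from one core to the other in this small set, but two pairs are a narrow base, and they show neither why the number rises nor that the same step would appear on any further core.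

The compounds shown leave open how other groups in place of the methyl, such as ethyl, a chlorine atom or a nitrile, would fare on either core. They also leave open whether the step would hold on a core with a longer chain, and whether it would appear in any read-out other than this calcium-based one.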